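This account rests on a few compounds, and the source may have more. Where it says the series, first, only, none or still open, it means among the compounds named here.

Measured so far:
compound 1, `CCCCCCCCc1ccc(OCC(=O)Cn2ncnn2)cc1`: < 5%
compound 2, `CCCCCCCCc1ccc(OCC(=O)Cn2nnc(-c3ccccc3Cl)n2)cc1`: 28%

In an ADME assay on S9 fraction from liver (Rattus norvegicus) for metabolic stability, read by LC-MS, using NADPH, with a stated time of 30 min (on this read-out higher numbers stand for a more stable compound and lower numbers for a less stable compound), compound 1 gives < 5%, which is a limit of the assay rather than a number (the limit of < 5% in this assay, at which 1 of the 2 values shown sits). Compound 3, `CCCCCCCCc1ccc(OCC(=O)Cn2nnc(-c3cccnc3)n2)cc1`, differs from compound 1 in one place: pyridin-3-yl in place of hydrogen on an aromatic carbon. Among the compounds with values here, the one measured step that bears on this change is a number at least 23 percentage points higher from compound 1 to compound 2 (beyond the scatter). A rise of similar kind is therefore expected for compound 3, beyond the scatter. The estimate for compound 3 is 20%, within 5% to 45%. The expected step is a number at least 15 percentage points higher from compound 1 to compound 3 (beyond the scatter).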

Compound 3, percent of the compound remaining: 12%
Compound 3: the middle estimate sits 8 percentage points above what was measured, and the stated range covers the measured number.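

In this assay, the kind of aromatic ring on this carbon matters, not just the presence of a ring: pyridin-3-yl in place of 2-chlorophenyl gives a number 16 percentage points lower from compound 2 to compound 3 (beyond the scatter). Pyridin-3-yl in place of hydrogen gives a number at least 7 percentage points higher from compound 1 to compound 3 (that floor lies within the scatter), so a rise beyond the scatter is not established for this group. That step is only a floor, because compound 1 stands at a limit of the assay: the limit of < 5% in this assay, at which 1 of the 3 values shown sits.

The compounds shown leave open what plain phenyl or an amine on this carbon would give in this assay. They also leave open whether the chlorine or the ring nitrogen separates compound 2 from compound 3.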